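Isoxazolopyridine ureas: from compound 2 toward compound 4

The source may report more compounds than this note shows. Statements on the series, on what has been measured and on what is new or still open speak of the compounds shown alone.

The three measured piperazine ureas share one core and differ only in the aromatic group on the urea nitrogen. In an assay on isolated protein for inhibition of Fatty-acid amide hydrolase 1 (Homo sapiens), with a stated time of 60 min (on this read-out lower numbers stand for stronger inhibition and higher numbers for weaker inhibition), compound 1 `O=C(Nc1cccc2nonc12)N1CCN(Cc2cccc(Oc3ccc(Cl)cc3)c2)CC1` gives 28 nM, compound 2 `O=C(Nc1cccc2cn[nH]c12)N1CCN(Cc2cccc(Oc3ccc(Cl)cc3)c2)CC1` gives 1300 nM, and compound 3 `O=C(Nc1noc2cnccc12)N1CCN(Cc2cccc(Oc3ccc(Cl)cc3)c2)CC1` gives 0.5 nM. Compound 2 therefore stands at the highest number of the three: a 46-fold higher number from compound 1 to compound 2 (1.67 log units; beyond the scatter), and a 2600-fold lower number from compound 2 to compound 3 (3.41 log units; beyond the scatter). Between the other two, a 56-fold lower number from compound 1 to compound 3 (1.75 log units; beyond the scatter).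

Compound 4 `O=C(Nc1noc2cccnc12)N1CCN(Cc2cccc(Oc3ccc(Cl)cc3)c2)CC1` is not yet measured. It differs from compound 2 in one place: a group of 9 heavy atoms (6 carbon, 2 nitrogen, 1 oxygen; one five-membered aromatic ring with 2 hetero atoms, one six-membered aromatic ring with 1 hetero atom) in place of a group of 9 heavy atoms (7 carbon, 2 nitrogen; one five-membered aromatic ring with 2 hetero atoms, one six-membered aromatic ring of carbon only), on an amide-type nitrogen. The entering group has the same composition of atoms and rings as the group that enters in the step to compound 3, so the step from compound 2 to compound 3 is the one that bears most directly, and it was large; the step from compound 1 to compound 2 points the same way, with compound 2 as the weaker end.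

A large downward step is therefore expected in this assay, a 430-fold lower number from compound 2 to compound 4 (2.64 log units; beyond the scatter), though not necessarily the full size seen for compound 3. Compound 4 is estimated at 3 nM, with a range of 0.4 nM to 30 nM.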

Compound 4, half-maximal inhibitory concentration: 13 nM
For compound 4 the middle estimate is 4.3-fold (0.64 log units) below the measured one; the measured number falls inside the stated range.
By their numbers in this assay, from the lowest: compound 3; then compound 4; then compound 1; then compound 2.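

In this assay, the two entering groups in compound 3 and compound 4 have the same counts of atoms and rings, yet the listed comparison gives a 26-fold higher number from compound 3 to compound 4 (1.41 log units; beyond the scatter) at this amide-type nitrogen, so those counts alone do not fix the number and the arrangement of the atoms within the group matters. Exchanging the 1H-indazol-7-yl group still gives a 100-fold lower number from compound 2 to compound 4 (2.00 log units; beyond the scatter) and thus keeps a large gain over compound 2, while a 2.2-fold lower number from compound 1 to compound 4 (0.33 log units; beyond the scatter) shows only a modest change, placing compound 4 much nearer to compound 1 than to compound 3 in this small set. No measured property or other supporting data on hand accounts for these differences.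

Going by these compounds, whether the order of compound 3 and compound 4 holds when the remainder of the shared core changes remains open. Also open, on these data alone, is how a methyl, a methoxy or an amine on the six-membered ring of the entering group would affect the number at this amide-type nitrogen.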